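The source may hold more compounds than are shown below. What is called first, only, known or untested is meant among the compounds shown, and "the series" means these compounds.

Measured so far in an assay on isolated protein for inhibition of prostaglandin G/H synthase 1 (Mus musculus), tested at 10 ug/mL; a higher number here means more inhibition at the concentration tested (going by the name of the read-out), a lower number less inhibition:
compound 1 `CS(=O)(=O)c1ccc(-c2oc3ccccc3c(=O)c2-c2cccc(Cl)c2)cc1` gives < 5%, a limit of the assay.
compound 2 `NS(=O)(=O)c1ccc(-c2oc3ccccc3c(=O)c2-c2ccccc2)cc1` gives 61%.
compound 3 `COc1ccc(-c2c(-c3ccc(S(C)(=O)=O)cc3)oc3ccccc3c2=S)cc1` gives < 5%, again a limit.

Compound 1 stands at the floor of this assay: its result is a limit, not a number, and (the limit of < 5% in this assay, at which 2 of the 3 values shown sit). Compound 2, with its own sulfonyl group, is the only one of the three that returns a number. Compound 4 `CS(=O)(=O)c1ccc(-c2oc3ccccc3c(=O)c2-c2cc(Cl)cc(Cl)c2)cc1` is still to be measured in this assay ; it differs from compound 1 by chloro in place of hydrogen on an aromatic carbon. Among the measured compounds shown here, no step between measured compounds can be read, so the step from compound 1 to compound 4 is expected to be none beyond the scatter, compound 4 staying at the limit. The expected step is a number no lower from compound 1 to compound 4 (the limit leaves the size open). Compound 4 is estimated at 5%, in the range 0% to 15%.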

Compound 4, a percentage reported as inhibition, at one concentration (the size of the read-out at that concentration, not a potency): < 5%
Compound 4: a limit, no number (the forecaster's own chance of this, stated with the estimate: 70%); the middle value sits exactly at the limit.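

Compound 1 and compound 4 both return a limit, not a number, in this assay, so no step between them can be read: the limit of < 5% in this assay, at which 3 of the 4 values shown sit.

The compounds shown leave open whether going from 3-chlorophenyl to 3,5-dichlorophenyl changes inhibition at all.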